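A few compounds are considered here, and "the series" means these few. Any claim that something is new, unique, unknown or untested is made for them only; others in the source may bear on it.

Measured so far:
compound 1 `COc1ccc(-c2cnn3c(NCc4ccccn4)cc(C)nc23)cc1`: in a physicochemical assay for solubility, read by HPLC, using the shake flask method, measured as kinetic solubility, with a stated time of 2 h, at pH 7.4 (on this read-out higher numbers stand for higher solubility and lower numbers for lower solubility), compound 1 gives < 5000 nM, a limit of the assay rather than a number.
compound 2 `Cc1cc(NCc2ccccn2)n2ncc(-c3ccco3)c2n1`: compound 2 gives 48800 nM.
compound 3 `Cc1cc(NCc2ccccn2)n2ncc(-c3cccc(N(C)C)c3)c2n1`: compound 3 gives 94600 nM.

Compound 3 holds the highest of the two numbers in this assay, but compound 2 lies within the scatter of it, so no order between the two is claimed; compound 1 contributes only a limit (the limit of < 5000 nM in this assay, at which 1 of the 3 values shown sits).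

The next step, to compound 4 `Cc1cc(NCc2ccccn2)n2ncc(-c3ccc(F)cc3C)c2n1`, is 4-fluoro-2-methylphenyl in place of 3-(dimethylamino)phenyl on an aromatic carbon. Within the data shown here, two measured steps bear on an aryl swap at this place. The step of an at least 18-fold higher number from compound 1 to compound 3 (1.27 log units; beyond the scatter) shows that such a swap can move the number a long way, while a 1.9-fold higher number from compound 2 to compound 3 (0.29 log units; within the scatter) shows another swap that moved it hardly at all. Compound 1 and compound 4 both carry a phenyl ring bearing only small substituents, and compound 1 sits at the limit; the balance of these steps therefore points to a lower number for compound 4 than for compound 3, with wide uncertainty. Compound 4 is expected to give about 10000 nM in this assay, within a range of 2500 nM to 45000 nM. The expected step is a 9.5-fold lower number from compound 3 to compound 4 (0.98 log units; beyond the scatter), and a limit read-out is a real possibility.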

Compound 4, solubility: 42300 nM
Compound 4: middle estimate off by 4.2-fold (0.63 log units), on the low side; the measured number falls inside the stated range.
By their numbers in this assay, from the lowest: compounds 4, 2 and 3 (each within the scatter of the next, the first and the last beyond it). At a limit, below all of these: compound 1.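

Carrying a substituted phenyl ring at this place does not by itself hold the number down in this assay: an at least 8.4-fold higher number from compound 1 to compound 4 (0.92 log units; beyond the scatter), and the compound 1 end of that step is a limit of the assay, not a number. The 4-fluoro-2-methylphenyl and furan-2-yl groups cannot be told apart on this read-out, with a 1.2-fold lower number from compound 2 to compound 4 (0.06 log units; within the scatter). Against 3-(dimethylamino)phenyl the change gives a 2.2-fold lower number from compound 3 to compound 4 (0.35 log units; beyond the scatter), so the dimethylamino group is not required for a number well clear of the limit, as compounds 2 and 4 both show.

The compounds shown do not separate the fluorine from the methyl of 4-fluoro-2-methylphenyl, as compound 4 carries both. From the compounds shown here alone, how a saturated amine such as morpholine or a carboxylic acid on this aromatic carbon would read remains open.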